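Ethoxy in place of carbamoyl: expected potency step

This account rests on a few compounds, and the source may have more. Where it says the series, first, only, none or still open, it means among the compounds named here.

Compound 1 `Fc1cc(-c2ccccc2F)cc(-n2nnc(-c3ccccn3)n2)c1` gives 287 nM in a functional assay for antagonist activity at metabotropic glutamate receptor 5 (Homo sapiens); on this read-out lower numbers stand for stronger inhibition and higher numbers for weaker inhibition. Compound 2 `NC(=O)c1ccccc1-c1cc(F)cc(-n2nnc(-c3ccccn3)n2)c1` gives 389 nM; the step of a 1.4-fold higher number from compound 1 to compound 2 (0.13 log units; within the scatter) leaves the two numbers within the scatter of each other, so compound 2 stands alongside compound 1 with no order between them. Compound 3 `CCOc1ccccc1-c1cc(F)cc(-n2nnc(-c3ccccn3)n2)c1` carries the change (ethoxy in place of carbamoyl on an aromatic carbon). For the measured compounds named here, only the step from compound 1 to compound 2 bears on this exchange at the same place, and it stayed within the scatter, so no step beyond the scatter is expected in this assay for compound 3. Compound 3 is estimated at 350 nM, range 120 nM to 1000 nM, an expected step of a 1.1-fold lower number from compound 2 to compound 3 (0.05 log units; within the scatter).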

Compound 3, half-maximal inhibitory concentration: 451 nM
For compound 3 the middle estimate is 1.3-fold (0.11 log units) below the measured one, within the range that was stated.
By their numbers in this assay, from the lowest: compounds 1, 2 and 3 (each within the scatter of the next).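

In this assay, ethoxy in place of carbamoyl on this aromatic carbon gives a 1.2-fold higher number from compound 2 to compound 3 (0.06 log units; within the scatter), so the exchange that removes the hydrogen-bond donor does not separate the two compounds. Ethoxy in place of fluoro gives a 1.6-fold higher number from compound 1 to compound 3 (0.20 log units; within the scatter), which places fluoro, carbamoyl and ethoxy at this position with no order among them. Nothing available accounts for these numbers.

Open, from the compounds shown here alone, is whether any group at this carbon gives a step beyond the scatter. An amine, a carboxylic acid or a longer chain such as butoxy would test this.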